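The source may report more compounds than this note shows. Statements on the series, on what has been measured and on what is new or still open speak of the compounds shown alone.

Measured in a functional assay on MDA-MB-231 cells (Homo sapiens) for antiproliferative activity, read by MTT assay, with a stated time of 24 h; on this read-out lower numbers stand for stronger inhibition and higher numbers for weaker inhibition:
- Compound 1 `CCCCc1oc2ccccc2c1C(=O)c1ccc(OCC(=O)N2CCCC2)cc1`: > 50000 nM
- Compound 2 `CCCCc1oc2ccccc2c1C(=O)c1ccc(OCC(=O)N2CCOCC2)cc1`: > 50000 nM
- Compound 3 `CCCCc1oc2ccccc2c1C(=O)c1ccc(OCC(=O)N[C@@H](C)c2ccccc2)cc1`: > 50000 nM

Each of these entries is a limit of the assay and not a number, and the set shares one reading: the limit of > 50000 nM in this assay, at which 3 of the 3 values shown sit. Compound 3 stands at > 50000 nM, which is a limit, so it cannot be ranked against the other two.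

The next compound is compound 4 `CCCCc1oc2ccccc2c1C(=O)c1ccc(OCCCC(=O)N2CCOCC2)cc1`, and the change is 2-((morpholin-4-yl)carbonyl)ethyl in place of (1-phenylethyl)carbamoyl on a saturated chain carbon bound to an oxygen on an aromatic ring. In words, 2-((morpholin-4-yl)carbonyl)ethyl replaces (1-phenylethyl)carbamoyl on a saturated chain carbon bound to an oxygen on an aromatic ring.

Three measured steps swap the group on the carbonyl carbon and bear on this change: a step that the two limits leave unreadable from compound 1 to compound 2, a step that the two limits leave unreadable from compound 1 to compound 3 and a step that the two limits leave unreadable from compound 2 to compound 3. For the measured compounds named here, none has a readable size, so they point in no direction, and no measured compound carries the entering group. The expectation therefore rests on the limit of compound 3 at > 50000 nM.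

No step beyond the usual scatter is expected in this assay, and the estimated step is a number no higher from compound 3 to compound 4 (the limit leaves the size open). A reported limit is again the likeliest result. If a number appears, the expected value for compound 4 is 50000 nM. The estimated range runs from 20000 nM to 100000 nM.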

Compound 4, half-maximal inhibitory concentration: 31600 nM
The estimate for compound 4 lay 1.6-fold (0.20 log units) above the measured number, within the range that was stated.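

Compound 4 is the first compound in this set to give a number rather than a limit in this assay: the limit of > 50000 nM in this assay, at which 3 of the 4 values shown sit.

The most direct comparison keeps the morpholin-4-yl amide and replaces (morpholin-4-yl)carbonyl with 2-((morpholin-4-yl)carbonyl)ethyl, and it gives an at least 1.5-fold lower number from compound 2 to compound 4 (0.19 log units; that floor lies within the scatter). Against the other two compounds, the same group gives an at least 1.5-fold lower number from compound 1 to compound 4 (0.19 log units; that floor lies within the scatter) and an at least 1.5-fold lower number from compound 3 to compound 4 (0.19 log units; that floor lies within the scatter), so this position can yield a readable number, while the limits leave the true size of all three steps open.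

The compounds shown leave open whether the longer chain would also give a number with a pyrrolidin-1-yl or (1-phenylethyl)amino group on its carbonyl, since only the morpholin-4-yl amide appears on it. They also leave open how a still longer chain, or a carboxylic acid in place of the amide, would read out at this position.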